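A Benzotriazole in Place of Benzylamine on a Quinoline Urea

This account rests on a few compounds, and the source may have more. Where it says the series, first, only, none or still open, it means among the compounds named here.

Compound 1 `COc1cc(NC(C)CCCNC(=O)NCc2ccccc2)c2ncccc2c1` and compound 2 `COc1cc(NC(C)CCCNC(=O)N(C2CCCCC2)C2CCCCC2)c2ncccc2c1` share the same core and were tested in a functional assay on CCRF-CEM cells (Homo sapiens), read by MTT assay, with a stated time of 72 h; a lower number here means a stronger inhibitor, a higher number a weaker inhibitor. In this assay compound 1 gives 18000 nM, and compound 2 gives 13000 nM; the two numbers lie within the usual scatter of each other, so neither can be called the stronger. Compound 3 `COc1cc(NC(C)CCCNC(=O)n2nnc3ccccc32)c2ncccc2c1` differs from compound 1 by a group of 9 heavy atoms (6 carbon, 3 nitrogen; one five-membered aromatic ring with 3 hetero atoms, one six-membered aromatic ring of carbon only) in place of a group of 8 heavy atoms (7 carbon, 1 nitrogen; one six-membered aromatic ring of carbon only), on a carbonyl carbon. Among the measured compounds shown here, no measured pair shows what such a change does here, so the expected step of a 1.2-fold lower number from compound 1 to compound 3 (0.08 log units; within the scatter) is none beyond the scatter. Compound 3 is therefore estimated at 15000 nM, with a range from 5000 nM to 45000 nM.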

Compound 3, half-maximal inhibitory concentration: > 100000 nM
Compound 3 ended at the assay's limit; the forecaster's own chance of this, stated with the estimate: 10%; middle value at least 6.6-fold (0.82 log units) from the limit.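

On this carbonyl carbon the choice of group clearly counts: in this assay the change gives an at least 5.5-fold higher number from compound 1 to compound 3 (0.74 log units; beyond the scatter), whereas the values of compounds 1 and 2 lay within the scatter of each other. The entering group has no hydrogen-bond donor, while benzylamino has one. The value of compound 3 is a limit of the assay and not a number: the limit of > 100000 nM in this assay, at which 1 of the 3 values shown sits.

The compounds shown cannot separate the loss of that donor from the change of ring. An anilino group, which has a nitrogen hydrogen and a benzene ring, would help to tell these two apart.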